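The source may report more compounds than this note shows. Statements on the series, on what has been measured and on what is new or still open speak of the compounds shown alone.

Measured in an ADME assay on MT4 cells (Homo sapiens) for cytotoxicity, read by MTT assay, with a stated time of 5 days (a lower number here means that less compound is tolerated, a higher number that more compound is tolerated), all three values being limits:
- compound 1 `COc1cc2cc(C#N)ccc2c(OC)c1Oc1cc(NC(C)C)nc(Nc2ccc(C#N)cc2)n1`: > 125000 nM
- compound 2 `COc1cc2cc(C#N)ccc2c(OC)c1Oc1cc(NCC(C)C)nc(Nc2ccc(C#N)cc2)n1`: > 125000 nM
- compound 3 `CCC(C)Nc1cc(Oc2c(OC)cc3cc(C#N)ccc3c2OC)nc(Nc2ccc(C#N)cc2)n1`: > 125000 nM

Compound 3 has no numerical value, only a limit, and it shares that position with the other two compounds: the limit of > 125000 nM in this assay, at which 3 of the 3 values shown sit.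

The next step leads to compound 4 `CCCC(C)Nc1cc(Oc2c(OC)cc3cc(C#N)ccc3c2OC)nc(Nc2ccc(C#N)cc2)n1`. The change is methyl in place of hydrogen on a saturated chain carbon, three bonds along the chain from a nitrogen on an aromatic ring, which reads as sec-butyl to 1-methylbutyl when cut one bond further out.

The closest measured precedent is the same methyl for hydrogen exchange, two bonds along the chain from a nitrogen on an aromatic ring: a step that the two limits leave unreadable from compound 1 to compound 3. The two changes among the larger groups on that nitrogen are a step that the two limits leave unreadable from compound 1 to compound 2 and a step that the two limits leave unreadable from compound 2 to compound 3. None of these steps has a readable size, so they give neither a direction nor a magnitude. They show only that no tolerated concentration has yet been resolved in this assay for this small set.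

On that basis, no step beyond the scatter is expected, and the estimated change is a number no higher from compound 3 to compound 4 (the limit leaves the size open). Another report as a limit is the likeliest outcome. For compound 4 the expected value is 125000 nM, with an estimated range of 50000 nM to 250000 nM.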

Compound 4, half-maximal cytotoxic concentration: > 125000 nM
Compound 4: only a limit was reported; the forecaster's own chance of this, stated with the estimate: 80%; the middle value sits exactly at the limit.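

In this assay compound 4 gives > 125000 nM, a limit and not a number. No step from compound 1, compound 2 or compound 3 to compound 4 can be read, and all four compounds share one position: the limit of > 125000 nM in this assay, at which 4 of the 4 values shown sit.

The compounds shown leave open whether the groups on the nitrogen differ at all in this assay.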